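Working notes: from compound 2 to compound 3

This account rests on a few compounds, and the source may have more. Where it says the series, first, only, none or still open, it means among the compounds named here.

Compound 1 (`COc1ccc(-c2nc3ccccc3o2)cc1NC(=O)c1cc([N+](=O)[O-])ccc1Cl`): > 25000 nM as a limit
Compound 2 (`Cc1ccc(-c2nc3ccccc3s2)cc1NC(=O)c1cc([N+](=O)[O-])ccc1Cl`): > 14000 nM as a limit

In an ADME assay on BJ cells (Homo sapiens) for cytotoxicity, with a stated time of 72 h (on this read-out lower numbers stand for an effect already at smaller amounts and higher numbers for an effect only at larger amounts of compound), compound 2 gives > 14000 nM as a limit and not a number. Compound 1 also gives > 25000 nM as a limit and not a number. Going by the values given here, neither compound has a measured number, so no measured step is available.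

Compound 3 (`Cc1ccc(-c2nc3ccccc3o2)cc1NC(=O)c1cc([N+](=O)[O-])ccc1Cl`) carries 1,3-benzoxazol-2-yl in place of 1,3-benzothiazol-2-yl on an aromatic carbon. In this assay no step beyond the scatter is expected for this change. The estimate means an expected step that the limit leaves unreadable from compound 2 to compound 3 and no more than that. For compound 3 the estimated value is 20000 nM with an expected range of 11000 nM to 35000 nM in this series.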

Compound 3, half-maximal effective concentration: > 14000 nM
Compound 3: only a limit was reported; the forecaster's own chance of this, stated with the estimate: 75%; the middle value lies beyond the limit too.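

Going by these compounds alone, compound 1, compound 2 and compound 3 all stand as limits in this assay, and no step between them can be read. The compounds shown leave open whether 1,3-benzoxazol-2-yl in place of 1,3-benzothiazol-2-yl, or methyl in place of methoxy, changes the read-out at all.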